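Solubility notes: from compound 3 to compound 4

The source may hold more compounds than are shown below. What is called first, only, known or untested is meant among the compounds shown, and "the series" means these compounds.

Three compounds of the series have been run in a physicochemical assay for solubility, at pH 7; a lower number here means a less soluble compound, a higher number a more soluble compound. Compound 1 `O=C(CN1CCC(c2ccccc2)(c2ccccc2)C1=O)N1CCN(C(c2ccccc2)c2ccc(F)cc2)CC1` sits at the limit of the assay, with a reading of < 25000 nM. Compound 2 `O=C(CN1CCC(c2ccccc2)(c2ccccc2)C1=O)N1CCN(Cc2cccc(C(F)(F)F)c2)CC1` likewise returns only a limit, < 25000 nM. Compound 3 `O=C(CN1CCCC(c2ccccc2)(c2ccccc2)C1=O)N1CCN(Cc2cccc(Cl)c2)CC1` also gives a limit, < 25000 nM, so that no number is known for it and no ordering among the three can be drawn; the common standing is summarised by the limit of < 25000 nM in this assay, at which 3 of the 3 values shown sit. Going by the values given here, no pair of measured compounds differs in a single place, so no measured step is available.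

Compound 4 `O=C(CN1CCCC(c2ccccc2)(c2ccccc2)C1=O)N1CCN(Cc2ccc(C(F)(F)F)cc2)CC1` is the next member. It departs from compound 3 by 4-(trifluoromethyl)phenyl in place of 3-chlorophenyl on a saturated chain carbon bound to an amine nitrogen in a ring. Among the compounds with values here, with every measured value resting at a limit, there is no step in this assay to lean on, and there is no ground here to expect a shift beyond the scatter in either direction; the most that can be said is that compound 4 is expected to land in the same low region as the three measured compounds. The estimate for compound 4 in this assay is 10000 nM, with a range from 2500 nM to 25000 nM. As a step this estimate means a step that the limit leaves unreadable from compound 3 to compound 4, and the reading is expected most likely to come back once more as a limit rather than as a number.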

Compound 4, solubility: < 25000 nM
Compound 4: no number, only a limit (the forecaster's own chance of this, stated with the estimate: 80%); the middle value is on the limit's open side.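

In this assay compound 4 returns < 25000 nM as a limit and not a number. Going by these compounds alone, compound 3 also gives only a limit, so no step from compound 3 to compound 4 can be read. The compounds shown leave open how far each lies under that limit and whether any change of group moves the reading, since all rest on one bound: the limit of < 25000 nM in this assay, at which 4 of the 4 values shown sit.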